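The source may report more compounds than this note shows. Statements on the series, on what has been measured and on what is new or still open speak of the compounds shown alone.

Series notes: the shared core of compound 1 `CC1=C(C(=O)C2CC2)C(c2ccco2)NC(=O)N1` carries a carbonyl carbon bearing a variable group, and the three measured compounds differ only there. In an assay on membranes from CHO cells for displacement of a labelled ligand from adenosine receptor A1 (Homo sapiens), read by scintillation counting, with a stated time of 60 min, tested at 1 uM (on this read-out higher numbers stand for more inhibition at the one concentration tested (going by the name of the read-out) and lower numbers for less inhibition), compound 1 gives 2%. Compound 2 `CCN(CC)C(=O)C1=C(C)NC(=O)NC1c1ccco1` gives 11% in this assay, and compound 3 `CCSC(=O)C1=C(C)NC(=O)NC1c1ccco1` gives 6%. Among the compounds with values here, the three numbers sit within the scatter of one another: the step of a number 9 percentage points higher from compound 1 to compound 2 (within the scatter), the step of a number 4 percentage points higher from compound 1 to compound 3 (within the scatter) and the step of a number 5 percentage points lower from compound 2 to compound 3 (within the scatter) are each within the usual spread of repeated measurements, so no compound can be set apart from the others, and compound 3 stands among them without a distinguishable place.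

The next compound, compound 4 `CCC(C)OC(=O)C1=C(C)NC(=O)NC1c1ccco1`, differs from compound 3 by sec-butoxy in place of ethylsulfanyl on a carbonyl carbon. All three measured steps bear on this change, since each of them replaces the group on this same carbonyl carbon; none of them moved the read-out beyond the scatter. Within the data shown here, the change to sec-butoxy is of the same kind, an exchange of a small group on that carbon, and nothing among the measured compounds points to a shift in either direction. The expectation is therefore a step of no change at the digits printed from compound 3 to compound 4 (within the scatter) that is itself within the scatter. Compound 4 is estimated to give 6% in this assay, with a range from -5% to 17%.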

Compound 4, a percentage reported as inhibition, at one concentration (the size of the read-out at that concentration, not a potency): 6%
Estimate against measurement, compound 4: no gap at the digits printed; the range from low to high includes it.
By their numbers in this assay, from the lowest: compounds 1, 3, 4 and 2 (each within the scatter of the next).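

In this assay, the group on the carbonyl carbon is now sec-butoxy, with 5 heavy atoms and an oxygen against 3 heavy atoms and a sulfur in ethylsulfanyl, and this exchange gives no change at the digits printed from compound 3 to compound 4 (within the scatter). The comparisons with the other two groups give a number 5 percentage points lower from compound 2 to compound 4 (within the scatter) and a number 4 percentage points higher from compound 1 to compound 4 (within the scatter), so cyclopropyl, diethylamino, ethylsulfanyl and sec-butoxy on this carbonyl carbon still cannot be told apart on this read-out, and the larger group with no ring adds no separation. No measurement at hand bears on why the read-out does not separate these groups.

On these data alone, whether a carboxylic acid, a primary amide or a longer alkoxy chain on this carbonyl carbon would move the number beyond the scatter stays open. Also open are the effect of a change elsewhere on the shared core and the potency of any of these compounds, since a reading at one concentration gives only the size of the inhibition there.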